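The source may hold more compounds than are shown below. What is called first, only, known or untested is meant among the compounds shown, and "the series" means these compounds.

Measured so far: compound 1 `COc1cccc(C(=O)Oc2cc3c(cc2C)[C@@H](C(C)C)CC=C3C)c1`, "not active" (no number reported); compound 2 `CC1=CC[C@H](C(C)C)c2cc(C)c(OC(=O)c3ccc(C)cc3)cc21`, 67.7%.

In a functional assay on U-251 cells (Homo sapiens) for antiproliferative activity, read by sulforhodamine B assay, with a stated time of 48 h, tested at 50 uM (a higher number here means more inhibition at the concentration tested (going by the name of the read-out), a lower number less inhibition), compound 2 gives 67.7%, the only number shown in this assay. Compound 1 is reported in this assay as "not active" (no number reported), with no number attached. Compound 3 `CC1=CC[C@H](C(C)C)c2cc(C)c(OC(=O)Nc3ccccc3)cc21` is not yet measured; it differs from compound 2 by anilino in place of 4-methylphenyl on a carbonyl carbon. Going by the values given here, no step between measured compounds is available, so the size of this change is unknown. A drop beyond the scatter is expected, as the other ester variant, compound 1, gives "not active" (no number reported). For compound 3 the expected value in this assay is 50%, within 15% to 80%. This estimate means a step of a number 17.7 percentage points lower from compound 2 to compound 3 (beyond the scatter).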

Compound 3, a percentage reported as inhibition, at one concentration (the size of the read-out at that concentration, not a potency): 100%
The estimate for compound 3 lay 50 percentage points below the measured number, outside the stated range (above it).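

Anilino in place of 4-methylphenyl on a carbonyl carbon gives a number 32.3 percentage points higher from compound 2 to compound 3 (beyond the scatter) in this assay. Going by these compounds alone, this is the first readable step at this position, and it shows that the group on the carbonyl carbon strongly affects the read-out at the concentration tested. Nothing available accounts for the rise.

As far as these compounds go, it remains open whether the amide hydrogen matters, which an N-methylanilino group would test. Also open, from the compounds shown here alone, is whether the aromatic ring is needed, which a cyclohexylamino or other saturated amine on the carbonyl carbon would address.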